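Isopropoxymethyl Substitution on the Shared Core

The source may hold more compounds than are shown below. What is called first, only, known or untested is meant among the compounds shown, and "the series" means these compounds.

Compound 1 `c1ccc2c(-c3cnc4[nH]nc(-c5nc6ccccc6[nH]5)c4c3)cncc2c1` has "not determined" (no result reported) in an assay on isolated protein for inhibition of proto-oncogene tyrosine-protein kinase receptor Ret (Homo sapiens); on this read-out higher numbers stand for weaker inhibition and lower numbers for stronger inhibition; no single number stands for it. Compound 2 `CN1CCN(c2ccc3[nH]c(-c4n[nH]c5ncc(-c6cncc7ccccc67)cc45)nc3c2)CC1`, a differently substituted member of the same series, gives 1000 nM in this assay. Compound 3 `CC(C)OCc1cccc2[nH]c(-c3n[nH]c4ncc(-c5cncc6ccccc56)cc34)nc12` differs from compound 1 by isopropoxymethyl in place of hydrogen on an aromatic carbon. Going by the values given here, no measured pair describes this change, so the direction of the step is open; a step within the usual scatter or a modest shift in either direction appears equally plausible. With compound 2 as the only anchor, compound 3 is expected to give about 800 nM in this assay, with a range from 150 nM to 4000 nM.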

Compound 3, half-maximal inhibitory concentration: > 100000 nM
Compound 3 ended at the assay's limit; the forecaster's own chance of this, stated with the estimate: 10%; middle value at least 120-fold (2.09 log units) away from the limit.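

No step can be read between compound 1 and compound 3: compound 1 has no single number, and compound 3 ends at a limit of the assay. The compounds shown leave open what isopropoxymethyl in place of hydrogen does to inhibition.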